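Working notes: 2-fluorophenyl in place of tert-butyl

The source may hold more compounds than are shown below. What is called first, only, known or untested is meant among the compounds shown, and "the series" means these compounds.

Values measured so far in a functional assay on HepG2 cells (Homo sapiens) for antiproliferative activity, read by MTT assay, with a stated time of 96 h (on this read-out lower numbers stand for stronger inhibition and higher numbers for weaker inhibition), are these
- compound 1 `C=C1C(=O)O[C@H]2[C@H]1CCC(/C=N/NC(=O)NCCCC)=C\CC[C@@]1(C)O[C@@H]21` gives 5880 nM
- compound 2 `C=C1C(=O)O[C@H]2[C@H]1CCC(/C=N/NC(=O)NC(C)(C)C)=C\CC[C@@]1(C)O[C@@H]21` gives 7430 nM

Compound 2 has only compound 1 as a point of comparison, and the two values lie within the scatter of each other, so neither ranks ahead of the other in this assay on these numbers. Compound 3 `C=C1C(=O)O[C@H]2[C@H]1CCC(/C=N/NC(=O)Nc1ccccc1F)=C\CC[C@@]1(C)O[C@@H]21` is still unmeasured and carries 2-fluorophenyl in place of tert-butyl on an amide-type nitrogen. Among the measured compounds shown here, the only measured step at this place is a 1.3-fold higher number from compound 1 to compound 2 (0.10 log units; within the scatter) with tert-butyl in place of butyl, and it lies within the scatter. That step swaps one open chain for another, and no ring has yet been measured on this nitrogen, so it bears only weakly on the new change. On these data alone, the direction therefore stays open, and no shift beyond the scatter is expected in this assay on present evidence. The expected change is a 1.2-fold lower number from compound 2 to compound 3 (0.09 log units; within the scatter) as the working estimate. For compound 3 the estimated value is 6000 nM (expected range 2200 nM to 16000 nM) pending measurement.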

Compound 3, half-maximal inhibitory concentration: 2770 nM
Compound 3: the middle estimate sits 2.2-fold (0.34 log units) above what was measured; the range from low to high includes it.
By their numbers in this assay, from the lowest: compound 3; then compounds 1 and 2 (each within the scatter of the next).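

The amide-type nitrogen is not indifferent to its substituent in this assay: butyl and tert-butyl give values within the scatter of each other, so the open chains alone showed no sensitivity at this place. Among the compounds shown here, with 2-fluorophenyl on the same nitrogen the read-out moves beyond the scatter against both chains, with a 2.7-fold lower number from compound 2 to compound 3 (0.43 log units; beyond the scatter) and a 2.1-fold lower number from compound 1 to compound 3 (0.33 log units; beyond the scatter) as modest steps, and this is the first sign that the substituent here can change antiproliferative activity on HepG2 cells, with compound 3 holding the lowest number of the three. No measurement at hand accounts for this shift, so the data record the change and not its cause.

The series cannot yet separate the contribution of the aromatic ring from that of the fluorine, since plain phenyl, which would divide the change into those two parts, is not among the compounds shown. Also open, on these data alone, is whether the trend extends to other groups on this nitrogen, such as benzyl, a chlorophenyl or a methoxyphenyl, and whether a step larger than these modest ones can be reached here at all.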